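Dropping one methoxy from the aryl ketone of compound 3

The source may hold more compounds than are shown below. What is called first, only, known or untested is meant among the compounds shown, and "the series" means these compounds.

Three compounds share one core and differ only in the aromatic ring on the carbonyl carbon. In a functional assay on NCI-H460 cells (Homo sapiens) for cytotoxicity, read by sulforhodamine B assay, with a stated time of 48 h, tested at 100 uM (a higher number here means a weaker effect of the compound at the concentration tested, a lower number a stronger effect), compound 1 `COc1cc(-c2cc(/C=C/C(=O)c3ccc(N)cc3)[nH]n2)cc(OC)c1OC` gives -59%, compound 2 `COc1cc(-c2cc(/C=C/C(=O)c3ccc(Cl)c(Cl)c3)[nH]n2)cc(OC)c1OC` gives -24%, and compound 3 `COc1ccc(C(=O)/C=C/c2cc(-c3cc(OC)c(OC)c(OC)c3)n[nH]2)cc1OC` gives -65%. Compound 3 has the lowest of the three numbers, but the gap to compound 1 is within the scatter, while the change a number 41 percentage points lower from compound 2 to compound 3 (beyond the scatter) is large. Compound 4 `COc1ccc(C(=O)/C=C/c2cc(-c3cc(OC)c(OC)c(OC)c3)n[nH]2)cc1` removes one group from compound 3: hydrogen in place of methoxy on an aromatic carbon. Within the data shown here, no measured step removes a single methoxy; the steps at this ring, a number 6 percentage points lower from compound 1 to compound 3 (within the scatter) and a number 41 percentage points lower from compound 2 to compound 3 (beyond the scatter), swap whole aryl groups and show that changes here can be either small or large. The remaining methoxy is kept, so only a modest step is expected for compound 4, a number 13 percentage points higher from compound 3 to compound 4 (beyond the scatter), towards a slightly higher number. Compound 4 is therefore estimated at -52% in this assay, with a range from -75% to -20%.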

Compound 4, a percentage reported as activity, at one concentration (the size of the read-out at that concentration, not a potency): -62%
Compound 4: the middle estimate sits 10 percentage points above what was measured; low and high end bracket the measured number.
By their numbers in this assay, from the lowest: compounds 3, 4 and 1 (each within the scatter of the next); then compound 2.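

In this assay, among these compounds, taking away one methoxy gives a number 3 percentage points higher from compound 3 to compound 4 (within the scatter) and is the first change here that touches a single group rather than a whole aryl ring. At this position, then, the 3,4-dimethoxyphenyl group can become 4-methoxyphenyl with no step beyond the scatter. The new compound also fits with the 4-aminophenyl compound, with a number 3 percentage points lower from compound 1 to compound 4 (within the scatter) as the step, while a number 38 percentage points lower from compound 2 to compound 4 (beyond the scatter) confirms that the 3,4-dichlorophenyl compound stands apart from the other three.

From the compounds shown here alone, whether the remaining methoxy matters stays open, as does the outcome with a hydroxyl, a fluorine or plain hydrogen in its place. Nothing measured here gives a reason for the size of these steps.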